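This account rests on a few compounds, and the source may have more. Where it says the series, first, only, none or still open, it means among the compounds named here.

Measured compounds:
Compound 1: `Nc1ccc(C(=O)/C=C/c2ccc(O)c(F)c2)cc1-c1ccc(F)cc1`, 11700 nM
Compound 2: `COc1ccc(/C=C/C(=O)c2ccc(N)c(-c3ccc(F)cc3)c2)cc1OC`, 3780 nM

Going by the values given here, in a functional assay on HepG2 cells (Homo sapiens) for cytotoxicity, read by sulforhodamine B assay, with a stated time of 48 h (on this read-out lower numbers stand for stronger inhibition and higher numbers for weaker inhibition), compound 2 gives 3780 nM, the lowest of the two numbers so far. Its nearest neighbour in this assay, compound 1, gives 11700 nM, a number that lies above that of compound 2 by more than the usual scatter. Compound 3, with structure `COc1ccc(/C=C/C(=O)c2ccc(N)c(-c3ccc(F)cc3)c2)cc1`, has not yet been measured in this assay. It differs from compound 2 in one place: hydrogen in place of methoxy on an aromatic carbon. The group that goes sits ortho to a methoxy group and meta to a large group. Among the compounds with values here, no measured pair in this set shows the effect of such a change, so the direction is open; a modest step from compound 2 to compound 3 in this assay of a 1.5-fold higher number from compound 2 to compound 3 (0.16 log units; within the scatter) is expected, leaning toward a somewhat higher number. Compound 3 is therefore estimated at 5500 nM, within a range from 2000 nM to 15000 nM.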

Compound 3, half-maximal inhibitory concentration: 3750 nM
The estimate for compound 3 lay 1.5-fold (0.17 log units) above the measured number; low and high end bracket the measured number.
By their numbers in this assay, from the lowest: compounds 3 and 2 (each within the scatter of the next); then compound 1.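

In this assay, hydrogen in place of methoxy, ortho to a methoxy group and meta to a large group, gives a 1.0-fold lower number from compound 2 to compound 3 (0.00 log units; within the scatter), so at this position the loss of that methoxy leaves the number within the scatter. The step of a 3.1-fold lower number from compound 1 to compound 3 (0.49 log units; beyond the scatter), with 4-methoxyphenyl in place of 3-fluoro-4-hydroxyphenyl on a double-bonded chain carbon bound to a double-bonded chain carbon, lies beyond the scatter, so this exchange, unlike the loss of the methoxy, moves the number measurably. No measurement at hand gives a reason for either step.

As far as these compounds go, whether an amine, a chlorine atom or a longer alkoxy chain at the position of the lost methoxy would also leave the number in place remains open. So does the effect of replacing the remaining methoxy group with hydrogen.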